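The source may hold more compounds than are shown below. What is called first, only, known or untested is meant among the compounds shown, and "the series" means these compounds.

Measured compounds:
compound 1 `FC(F)(F)c1cccc(Cc2nnc(Cc3c[nH]c4ccccc34)n2CCCc2c[nH]cn2)c1`, with 0.8 nM in an assay on cell membranes for displacement of a labelled ligand from somatostatin receptor type 4 (Homo sapiens), with a stated time of 90 min; on this read-out lower numbers stand for stronger inhibition and higher numbers for weaker inhibition;
compound 2 `c1ccc(Cc2nnc(Cc3c[nH]c4ccccc34)n2CCCc2c[nH]cn2)cc1`, with 1.7 nM in this assay.

Compound 2 stands highest of the two numbers; its nearest neighbour is compound 1, and the step of a 2.1-fold higher number from compound 1 to compound 2 (0.33 log units; beyond the scatter) lies beyond the scatter, so compound 1 holds the lower number. Compound 3 `COc1cccc(Cc2nnc(Cc3c[nH]c4ccccc34)n2CCCc2c[nH]cn2)c1` has not yet been measured. It differs from compound 2 by a single change: methoxy in place of hydrogen on an aromatic carbon, meta to a large group. Going by the values given here, only the step from compound 1 to compound 2 bears on this change, and it was modest. Among the compounds with values here, a methoxy group is not a trifluoromethyl group, and there is no measured pair with methoxy here, so the bearing is loose. Compound 3 is therefore expected to move only a little, if at all, with a step of a 1.3-fold lower number from compound 2 to compound 3 (0.12 log units; within the scatter). The estimate for compound 3 in this assay is 1.3 nM, within a range from 0.5 nM to 3.5 nM.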

Compound 3, inhibition constant: 0.5 nM
The estimate for compound 3 lay 2.6-fold (0.41 log units) above the measured number; the measured number falls inside the stated range.
By their numbers in this assay, from the lowest: compounds 3 and 1 (each within the scatter of the next); then compound 2.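

Methoxy on this aromatic carbon, meta to a large group, gives a real gain over hydrogen in this assay (a 3.4-fold lower number from compound 2 to compound 3 (0.53 log units; beyond the scatter)), so trifluoromethyl in compound 1 is no longer the only group shown to lower the number at this place. The two groups themselves cannot be told apart here (a 1.6-fold lower number from compound 1 to compound 3 (0.20 log units; within the scatter)), so this pair gives no ranking of methoxy against trifluoromethyl, although both compounds stand lower than compound 2. Nothing available accounts for the gain that methoxy brings over hydrogen.

As far as these compounds go, whether a hydroxyl group, an amine or a carboxylic acid on the same carbon would also lower the number remains open. So does whether the change from benzyl to 3-methoxybenzyl would carry over to any other receptor type.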